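Shrinking the Sulfur-Linked Group in a Cytotoxicity Series

A few compounds are considered here, and "the series" means these few. Any claim that something is new, unique, unknown or untested is made for them only; others in the source may bear on it.

Compound 1 `Cc1cc(N2CC[C@@H](C)[C@@H](N(C)c3ncnc4[nH]ccc34)C2)n2nc(SCC3CC3)nc2n1` gives 27900 nM in a toxicity assay on GES1 cells (Homo sapiens) for inhibition, read by MTT assay, with a stated time of 72 h; on this read-out higher numbers stand for weaker inhibition and lower numbers for stronger inhibition.
Compound 2 `Cc1cc(N2CC[C@@H](C)[C@@H](N(C)c3ncnc4[nH]ccc34)C2)n2nc(SCc3csc4ccc(Cl)cc34)nc2n1` gives > 100000 nM in this assay, which is a limit of the assay rather than a number.
Compound 3 `Cc1ccc(CSc2nc3nc(C)cc(N4CC[C@@H](C)[C@@H](N(C)c5ncnc6[nH]ccc56)C4)n3n2)cc1` gives 82500 nM in this assay.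

Compound 2 thus stands at the weak end of the three, reaching only (the limit of > 100000 nM in this assay, at which 1 of the 3 values shown sits). Compound 4 `CCCSc1nc2nc(C)cc(N3CC[C@@H](C)[C@@H](N(C)c4ncnc5[nH]ccc45)C3)n2n1` differs from compound 2 by ethyl in place of 5-chloro-1-benzothiophen-3-yl on a saturated chain carbon bound to a sulfur. Among the compounds with values here, two measured steps bear on this: an at least 3.5-fold higher number from compound 1 to compound 2 (0.55 log units; beyond the scatter) and a 3.0-fold higher number from compound 1 to compound 3 (0.47 log units; beyond the scatter), both running from the cyclopropyl compound toward a larger aromatic group with a higher number. Going the other way, toward a small chain, a lower number in this assay is expected, beyond the scatter. Compound 4 is therefore estimated at 30000 nM, between 12000 nM and 80000 nM. The expected step is an at least 3.3-fold lower number from compound 2 to compound 4 (0.52 log units; beyond the scatter).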

Compound 4, half-maximal inhibitory concentration: 67100 nM
Estimate against measurement, compound 4: 2.2-fold (0.35 log units) below; the range from low to high includes it.
By their numbers in this assay, from the lowest: compound 1; then compounds 4 and 3 (each within the scatter of the next). At a limit, above all of these: compound 2.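

Ring or no ring, group size alone does not set the number at this position: the ethyl group gives a 1.2-fold lower number from compound 3 to compound 4 (0.09 log units; within the scatter), yet a 2.4-fold higher number from compound 1 to compound 4 (0.38 log units; beyond the scatter), which leaves the cyclopropyl compound 1 alone with the lowest number. The remaining comparison reads an at least 1.4-fold lower number from compound 2 to compound 4 (0.17 log units; that floor lies within the scatter), and this is only a floor, because one end of it is a limit of the assay: the limit of > 100000 nM in this assay, at which 1 of the 4 values shown sits.

The compounds shown leave open whether the lower number of compound 1 goes with its small ring, which a cyclobutyl group or a longer chain in the same place could test. As far as these compounds go, how an amine on that chain would read also stays open.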